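Hydroxy for phenyl on the chalcone-type chromene series

The compounds below may be only part of what the source reports. "The series", "measured", "known", "first", "only" and "open" are said of these compounds alone.

The series shares one core, shown by compound 1 `COc1ccc(C(=O)/C=C/c2ccc(-c3ccccc3)cc2)c2c1C=CC(C)(C)O2` and compound 2 `COc1ccc(C(=O)/C=C/c2cccc3ccccc23)c2c1C=CC(C)(C)O2`. Both are tested for antiproliferative activity in a functional assay on HT-29 cells (Homo sapiens) for antiproliferative activity, read by MTT assay, with a stated time of 24 h; on this read-out lower numbers stand for stronger inhibition and higher numbers for weaker inhibition. In this assay compound 1 reaches only the limit of the assay, > 10000 nM, and no number. In this assay compound 2 likewise reaches only the limit, > 10000 nM. For the measured compounds named here, compound 1 therefore stands at the limit of > 10000 nM in this assay, at which 2 of the 2 values shown sit, together with the only other value known, so nothing in the measured pair separates one compound from the other, and no step between measured compounds can be drawn.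

Compound 3 `COc1ccc(C(=O)/C=C/c2ccc(O)cc2)c2c1C=CC(C)(C)O2` is not yet measured. It differs from compound 1 by hydroxy in place of phenyl on an aromatic carbon, the new group sitting on an aromatic carbon of a six-membered aromatic ring of carbon only, para to a large group. Going by the values given here, with no measured step, no direction can be read from the numbers; a step beyond the scatter in either direction is possible, but the more probable outcome is a value near the limit. Compound 3 is expected at 8000 nM, in the range 1500 nM to 30000 nM, which means an estimated step of an at least 1.2-fold lower number from compound 1 to compound 3 (0.09 log units; that floor lies within the scatter).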

Compound 3, half-maximal inhibitory concentration: > 10000 nM
Compound 3: only a limit was reported (the forecaster's own chance of this, stated with the estimate: 50%); at least 1.2-fold (0.09 log units) between middle value and limit.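

In this assay, for the compounds shown here, compound 3 gives > 10000 nM, which is a limit and not a number; compound 1 also stands at a limit, so no step from compound 1 to compound 3 can be read. The compounds shown leave open whether any change on the shared core gives a measurable value in this assay: the limit of > 10000 nM in this assay, at which 3 of the 3 values shown sit.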